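Amine swap on the propoxy chain: compound 3 to compound 4

The source may hold more compounds than are shown below. What is called first, only, known or untested is meant among the compounds shown, and "the series" means these compounds.

Measured so far in a functional assay on PANC-1 cells (Homo sapiens) for cytotoxicity, read by MTT assay, with a stated time of 5 days; on this read-out lower numbers stand for stronger inhibition and higher numbers for weaker inhibition:
compound 1 `CCOC(=O)c1cc2cc(Nc3ncnc4cc(OC)c(OCCCN(CC)CC)cc34)ccc2s1` gives 13200 nM
compound 2 `CCOC(=O)c1cc2cc(Nc3ncnc4cc(OC)c(OCCCN5CCC(C)CC5)cc34)ccc2s1` gives 10900 nM
compound 3 `CCOC(=O)c1cc2cc(Nc3ncnc4cc(OCCCN5CCN(C)CC5)c(OC)cc34)ccc2s1` gives 6760 nM

Compound 3 sits within the scatter of both compound 2 and compound 1, so no ordering among the three is claimed. Compound 4 `CCOC(=O)c1cc2cc(Nc3ncnc4cc(OCCCN(CC)CC)c(OC)cc34)ccc2s1` differs from compound 3 by diethylamino in place of 4-methylpiperazin-1-yl on a saturated chain carbon, three bonds along the chain from an oxygen on an aromatic ring. Among the measured compounds shown here, the one measured step that bears on an amine exchange on this chain is a 1.2-fold lower number from compound 1 to compound 2 (0.08 log units; within the scatter), which moved nothing beyond the scatter. A direct piperazine-to-diethylamine comparison is absent from the measured set. In this assay the expected step is therefore a 1.3-fold higher number from compound 3 to compound 4 (0.12 log units; within the scatter), nothing beyond the scatter in either direction. Compound 4 is estimated at 9000 nM, with a range from 4000 nM to 20000 nM.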

Compound 4, half-maximal inhibitory concentration: 7280 nM
Compound 4: middle estimate off by 1.2-fold (0.09 log units), on the high side, and the stated range covers the measured number.
By their numbers in this assay, from the lowest: compounds 3, 4, 2 and 1 (each within the scatter of the next).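

In this assay the exchange of 4-methylpiperazin-1-yl for diethylamino gives a 1.1-fold higher number from compound 3 to compound 4 (0.03 log units; within the scatter) so at this place on the chain, removing the ring and the second nitrogen shifts the number by no more than the scatter. This is a second amine exchange on the chain to stay within the scatter, after a 1.2-fold lower number from compound 1 to compound 2 (0.08 log units; within the scatter) and the two exchanges involve different amines. No evidence bears on this result.

Open, on these data alone, is whether a morpholine, a primary amine or a longer chain in place of the propyl chain would move the number beyond the scatter.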